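The source may report more compounds than this note shows. Statements on the series, on what has been measured and on what is new or still open speak of the compounds shown alone.

Working notes on the series. Compound 3 `Cc1ccccc1-c1c(C(=O)N(C)Cc2ccccc2)n(C)c(=O)c2ccccc12` gives 34 nM in an assay on IM-9 cells for binding affinity to Substance-P receptor (Homo sapiens); on this read-out lower numbers stand for stronger inhibition and higher numbers for weaker inhibition; it stands second highest of the three numbers, nearest compound 2 `Cc1ccccc1-c1c(C(=O)N(C)Cc2ccccc2Cl)n(C)c(=O)c2ccccc12` with 19 nM and furthest from compound 1 `COc1ccccc1CNC(=O)c1c(-c2ccccc2C)c2ccccc2c(=O)n1C` with 470 nM. Compound 4 `COc1ccccc1CN(C)C(=O)c1c(-c2ccccc2C)c2ccccc2c(=O)n1C` awaits measurement. The change: methoxy in place of hydrogen on an aromatic carbon, the methoxy entering ortho to a large group. Among the compounds with values here, two measured steps bear on it. a 1.8-fold higher number from compound 2 to compound 3 (0.25 log units; within the scatter) shows that a group on that aromatic carbon changes little here. a 14-fold lower number from compound 1 to compound 3 (1.14 log units; beyond the scatter) removed the methoxy together with adding a methyl on the amide nitrogen, so the methoxy's own share is not separable. Compound 4 is expected to sit close to compound 3, with a 1.2-fold higher number from compound 3 to compound 4 (0.07 log units; within the scatter) estimated as within the scatter, and an estimated value of 40 nM (range 15 nM to 110 nM).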

Compound 4, half-maximal inhibitory concentration: 16 nM
Compound 4: the middle estimate sits 2.5-fold (0.40 log units) above what was measured; the measured number falls inside the stated range.
By their numbers in this assay, from the lowest: compounds 4, 2 and 3 (each within the scatter of the next, the first and the last beyond it); then compound 1.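

In this assay, methoxy on this aromatic carbon, ortho to a large group, gives a 2.1-fold lower number from compound 3 to compound 4 (0.33 log units; beyond the scatter) as a modest step, whereas swapping chloro for methoxy there gives a 1.2-fold lower number from compound 2 to compound 4 (0.07 log units; within the scatter) and leaves the two groups not told apart. With the methoxy held constant, methyl in place of hydrogen on the amide-type nitrogen gives a 29-fold lower number from compound 1 to compound 4 (1.47 log units; beyond the scatter) as a single change, isolating the share of that methyl from the mixed earlier step. No measurement at hand explains either effect. Still open, as far as these compounds go, is whether a hydroxy group or an amine on this aromatic carbon would match methoxy and chloro, and whether an ethyl group on the amide-type nitrogen would hold the gain.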